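Swapping the amide aryl group: from methylphenyl to pyridyl

This account rests on a few compounds, and the source may have more. Where it says the series, first, only, none or still open, it means among the compounds named here.

Measured compounds:
compound 1 `CCc1cccc(NC(=O)CN2CCN(c3ccccn3)CC2)c1` with 1310 nM
compound 2 `Cc1cccc(NC(=O)CN2CCN(c3cccc4ccccc34)CC2)c1` with 2520 nM
compound 3 `Cc1cccc(NC(=O)CN2CCN(c3ccc(Cl)cn3)CC2)c1` with 4700 nM

These three compounds were tested in a functional assay on cells for antagonist activity at D(4) dopamine receptor (Homo sapiens), read by TR-FRET and cAMP accumulation, with a stated time of 30 min; a higher number here means a weaker inhibitor, a lower number a stronger inhibitor. Compound 3 gives the highest of the three numbers. Its nearest neighbour is compound 2, whose number is lower by an amount that stays within the usual scatter, so the two cannot be told apart. Compound 1 gives a number lower still, and this gap lies beyond the scatter, so compound 1 is a clearly stronger inhibitor than compound 3.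

The next compound to consider is compound 4 `O=C(CN1CCN(c2ccc(Cl)cn2)CC1)Nc1cccnc1`. It differs from compound 3 in one place: pyridin-3-yl in place of 3-methylphenyl on an amide-type nitrogen. The rest of the molecule, including the piperazine bearing the chloropyridine, is unchanged.

For the measured compounds named here, no pair among the measured compounds shows this particular change, so the data give no direct guide to its size. On the basis of the numbers available, a modest shift towards a weaker inhibitor is expected, though a result within the scatter of compound 3 would not surprise. The expected step from compound 3 to compound 4 in this assay is a 1.7-fold higher number from compound 3 to compound 4 (0.23 log units; within the scatter). Compound 4 is therefore estimated at 8000 nM, with a range from 2500 nM to 25000 nM.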

Compound 4, half-maximal inhibitory concentration: 40000 nM
Compound 4: the middle estimate sits 5.0-fold (0.70 log units) below what was measured; measured number above the stated range.
By their numbers in this assay, from the lowest: compounds 1, 2 and 3 (each within the scatter of the next, the first and the last beyond it); then compound 4.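

In this assay, the group on the amide-type nitrogen turns out to matter a great deal: pyridin-3-yl in place of 3-methylphenyl gives an 8.5-fold higher number from compound 3 to compound 4 (0.93 log units; beyond the scatter), a step well beyond the usual scatter. For the compounds shown here, this is the first pair in the set that differs in one place only, so it gives the first direct reading of this position, and it shows that a six-membered aromatic ring carrying one nitrogen and a hydrogen-bond acceptor cannot stand in for the 3-methylphenyl ring without a clear loss of inhibition. Nothing available here explains why the inhibitor becomes so much weaker.

The swap removes the methyl group and adds the ring nitrogen at once, so the compounds shown leave open which of the two changes carries the loss, and a plain phenyl group on the amide-type nitrogen would help to separate them. Also open, from the compounds shown here alone, is whether a pyridin-2-yl or pyridin-4-yl group would behave like pyridin-3-yl, and whether the step would be as large with another group on the piperazine.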